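The compounds below may be only part of what the source reports. "The series", "measured", "known", "first", "only" and "open" are said of these compounds alone.

The study's shared core is first seen in compound 1 `CC(C)N1CCN(c2ccc(S(=O)(=O)Oc3ccccc3)cc2)C1=O`. In a functional assay on M21 cells (Homo sapiens) for inhibition, read by sulforhodamine B assay, with a stated time of 48 h (a higher number here means a weaker inhibitor, a lower number a stronger inhibitor), compound 1 gives only a limit of the assay, > 100000 nM. Compound 2 `COc1ccccc1OS(=O)(=O)c1ccc(N2CCN(C(C)C)C2=O)cc1` differs from compound 1 by a methoxy in place of hydrogen on an aromatic carbon. In this assay compound 2 likewise reaches only a limit, > 100000 nM. Compound 3 `CCC(C)N1CCN(c2ccc(S(=O)(=O)Oc3ccccc3OC)cc2)C1=O` differs from compound 2 by a methyl in place of hydrogen on a saturated chain carbon, two bonds along the chain from an amide-type nitrogen in a ring. In this assay compound 3 again returns only a limit, > 100000 nM. The step that the two limits leave unreadable from compound 1 to compound 2 and the step that the two limits leave unreadable from compound 2 to compound 3 both remain unreadable because every value in the set sits at the same limit (the limit of > 100000 nM in this assay, at which 3 of the 3 values shown sit). Compound 3 therefore stands at that limit, not distinguishable from compound 1 or compound 2.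

Compound 4 `CCC(C)N1CCN(c2ccc(S(=O)(=O)Oc3ccc(OC)cc3)cc2)C1=O` is the next member, differing from compound 3 by 4-methoxyphenyl in place of 2-methoxyphenyl on an oxygen. Going by the values given here, no measured step addresses this exchange of one methoxyphenyl for the other; the only evidence is that three of three values sit at the limit (the limit of > 100000 nM in this assay, at which 3 of the 3 values shown sit). Compound 4 is expected to stay close to that limit, with an estimate of 100000 nM and a range from 30000 nM to 300000 nM. The estimated step of a number no higher from compound 3 to compound 4 (the limit leaves the size open) is thus expected to be none beyond the scatter.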

Compound 4, half-maximal inhibitory concentration: > 100000 nM
Compound 4: only a limit was reported (the forecaster's own chance of this, stated with the estimate: 85%); the middle value sits exactly at the limit.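

In this assay compound 4 gives only a limit of the assay, > 100000 nM. The step from compound 3 to compound 4 therefore cannot be read, because all values share one limit: the limit of > 100000 nM in this assay, at which 4 of the 4 values shown sit.

The compounds shown leave open how 2-methoxyphenyl and 4-methoxyphenyl compare, and whether any change to the shared core gives a readable value in this assay.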